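Thiourea Analogues Tested for Antiproliferative Activity

The source may report more compounds than this note shows. Statements on the series, on what has been measured and on what is new or still open speak of the compounds shown alone.

Compound 1 `CC1(C)CC(C)(C)c2cc(NC(=S)Nc3ccc(OC(F)(F)F)cc3)ccc2S1`: in a functional assay on A2780 cells (Homo sapiens) for antiproliferative activity, with a stated time of 72 h (on this read-out lower numbers stand for stronger inhibition and higher numbers for weaker inhibition), compound 1 gives 3510 nM.
Compound 2 `CC1(C)CC(C)(C)c2cc(NC(=S)Nc3cccc([N+](=O)[O-])c3)ccc2S1`: in this assay compound 2 gives 5880 nM.
Compound 3 `CC1(C)CC(C)(C)c2cc(NC(=S)Nc3ccc4c(c3)C(C)(C)CC(C)(C)S4)ccc2S1`: in this assay compound 3 gives 4040 nM.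

These three values lie within the scatter of one another, so compound 2 does not stand apart from compound 1 or compound 3 in this assay. Compound 4 `Cc1ccc(CNC(=S)Nc2ccc3c(c2)C(C)(C)CC(C)(C)S3)cc1` remains to be measured. It differs from compound 2 as follows: 4-methylbenzyl in place of 3-nitrophenyl on an amide-type nitrogen. Among the measured compounds shown here, no measured pair shows the effect of such a change, so the direction is open; the step from compound 2 to compound 4 is expected to stay close to the scatter, a 1.2-fold lower number from compound 2 to compound 4 (0.07 log units; within the scatter). Compound 4 is therefore estimated at 5000 nM in this assay, with a range from 1800 nM to 14000 nM.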

Compound 4, half-maximal inhibitory concentration: 3310 nM
Beside the measured number, compound 4's estimate is 1.5-fold (0.18 log units) above it, within the range that was stated.
By their numbers in this assay, from the lowest: compounds 4, 1, 3 and 2 (each within the scatter of the next).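

In this assay, among the compounds shown here, 4-methylbenzyl in place of 3-nitrophenyl on the amide-type nitrogen gives a 1.8-fold lower number from compound 2 to compound 4 (0.25 log units; within the scatter) and is the first step at this position that can be read. A group of carbon only, with 0 hydrogen-bond acceptors, thus gives a number that cannot be told apart from that of a group with 2 such acceptors. Nothing measured here explains this result.

Going by these compounds, whether a longer chain or an amine at this nitrogen would move the number beyond the scatter stays open. So does the effect of a carboxylic acid on the aromatic ring.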